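Methoxy Removal on the Arylidene Ring, Second Instance

The compounds below may be only part of what the source reports. "The series", "measured", "known", "first", "only" and "open" are said of these compounds alone.

Compound 1 `COc1ccccc1/C=C1\CN(CC(=O)O)c2c(C)cccc2C1=O`, compound 2 `COc1cc(/C=C2\CN(CC(=O)O)c3ccc(C)cc3C2=O)cc(OC)c1` and compound 3 `COc1ccc(OC)c(/C=C2\CN(CC(=O)O)c3c(C)cccc3C2=O)c1` have been run in an assay on HL-60 cells for inhibition of glutathione S-transferase P (Homo sapiens), read by spectrophotometry, tested at 20 uM; a lower number here means less inhibition, a higher number more inhibition at the concentration tested (going by the name of the read-out). In this assay compound 1 gives 4.72%, compound 2 gives 23.8% and compound 3 gives 5.44%. Compound 2 is highest of the three, beyond the scatter from both others. Compound 2 and compound 3 have the same atoms joined differently; the difference between their cores is not broken down here. From compound 3 to compound 1 the change is hydrogen in place of methoxy on an aromatic carbon; the step is a number 0.7 percentage points lower from compound 3 to compound 1 (within the scatter).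

Compound 4 `COc1cccc(/C=C2\CN(CC(=O)O)c3ccc(C)cc3C2=O)c1` has not yet been measured in this assay. It arises from compound 2 by hydrogen in place of methoxy on an aromatic carbon. This is the same kind of change as that from compound 3 to compound 1 but not the same: in compound 4 the carbon is meta to a methoxy group, in compound 1 it is para to a methoxy group. For compound 4 a small step is expected, a number 5.8 percentage points lower from compound 2 to compound 4 (within the scatter), because a number 0.7 percentage points lower from compound 3 to compound 1 (within the scatter) lay within the scatter. Starting from compound 2 at 23.8%, the estimate for compound 4 is 18%, between 6% and 30%.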

Compound 4, a percentage reported as inhibition, at one concentration (the size of the read-out at that concentration, not a potency): 14.4%
The estimate for compound 4 lay 3.6 percentage points above the measured number, and the stated range covers the measured number.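

The new step for hydrogen in place of methoxy on an aromatic carbon is a number 9.4 percentage points lower from compound 2 to compound 4 (within the scatter) in this assay. Set beside the earlier step, it gives no sign that the change behaves differently on the two cores: the same change on two cores in this assay, a number 0.7 percentage points lower (within the scatter) from compound 3 to compound 1 and a number 9.4 percentage points lower (within the scatter) from compound 2 to compound 4, 8.7 percentage points apart, within the scatter of two such steps. Within the data shown here, this does not show that the change is without effect or that it will carry over to other cores, since only two pairs are available and the methoxy group that leaves does not stand in the same place relative to the remaining methoxy group in both, so core and place cannot be separated.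

The compounds shown leave open how an amine, a fluorine or a longer chain such as ethoxy would read in place of methoxy on either core. They also leave open whether either step would hold with an ester or an amide in place of the carboxylic acid.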